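Swapping Trifluoromethoxy for Fluoro on a Shared Core

This account rests on a few compounds, and the source may have more. Where it says the series, first, only, none or still open, it means among the compounds named here.

Compound 1 `CC(c1ccc(-c2ccccc2)c(F)c1)c1nnc2n1N=C(c1ccc(OC(F)(F)F)cc1)CS2` is one of three compounds tested in a functional assay on HCT-116 cells (Homo sapiens) for inhibition, read by sulforhodamine B assay, with a stated time of 72 h; on this read-out higher numbers stand for weaker inhibition and lower numbers for stronger inhibition. In this assay compound 1 gives 5400 nM, the lower of the two numbers reported, though compound 3 `COc1ccc2cc(C(C)c3nnc4n3N=C(c3ccc(C(F)(F)F)cc3)CS4)ccc2c1`, which gives 10800 nM, lies within the usual scatter of it, so the two cannot be ranked. Compound 2 `CC(c1ccc(-c2ccccc2)c(F)c1)c1n[nH]c(=S)n1N` is reported as "not active" (no number reported) in this assay. Compound 4 `CC(c1ccc(-c2ccccc2)c(F)c1)c1nnc2n1N=C(c1ccc(F)cc1)CS2` differs from compound 1 by fluoro in place of trifluoromethoxy on an aromatic carbon. Among the measured compounds shown here, no measured pair shows this change, so its effect is uncertain; only a small shift is expected, with weaker inhibition slightly more likely than stronger. Compound 4 is estimated at 7500 nM in this assay, between 2500 nM and 25000 nM. This expected step a 1.4-fold higher number from compound 1 to compound 4 (0.14 log units; within the scatter) would be small.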

Compound 4, half-maximal inhibitory concentration: 10500 nM
Estimate against measurement, compound 4: 1.4-fold (0.15 log units) below; measured number inside the range.
By their numbers in this assay, from the lowest: compounds 1, 4 and 3 (each within the scatter of the next).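

In this assay, among the compounds shown here, the change from 4-(trifluoromethoxy)phenyl to 4-fluorophenyl gives a 1.9-fold higher number from compound 1 to compound 4 (0.29 log units; within the scatter), the first measured step at this position. The group here can therefore go from five heavy atoms to one without a difference that stands out from the scatter of repeated measurements. Nothing available explains this result. On these data alone, what an amine or a carboxylic acid in this place would give remains open. As far as these compounds go, it is also open whether the same swap would read alike on a different core.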